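This account rests on a few compounds, and the source may have more. Where it says the series, first, only, none or still open, it means among the compounds named here.

Measured compounds:
compound 1, `CC1CCC(=NNc2ccccc2)c2ncc(C(=O)O)c(=O)n21`, gives 0.6 umol/kg in a functional assay on the whole organism for inhibition, with Rattus norvegicus as the target; on this read-out higher numbers stand for an effect only at larger amounts of compound and lower numbers for an effect already at smaller amounts
compound 2, `O=C(O)c1cnc2n(c1=O)CCC/C2=N\Nc1ccccc1`, gives 31.6 umol/kg in this assay

Among the measured compounds shown here, compound 2 holds the higher of the two numbers measured so far. Compound 1, which also carries a methyl on its saturated ring, gives a number far lower than compound 2 does, and that gap lies well beyond the usual scatter of repeated measurements. The step under study leads from compound 2 to compound 3, `CC1C/C(=N\Nc2ccccc2)c2ncc(C(=O)O)c(=O)n2C1`, which has not yet been measured in this assay. The change is methyl in place of hydrogen on a saturated ring carbon. For the measured compounds named here, since the only other methyl-bearing compound on record is compound 1 with 0.6 umol/kg, a move toward lower numbers is expected, though with wide uncertainty since the methyl of compound 3 sits elsewhere. The expected step is a 5.3-fold lower number from compound 2 to compound 3 (0.72 log units; beyond the scatter). For compound 3 the estimate in this assay is 6 umol/kg, within a range from 1.5 umol/kg to 25 umol/kg.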

Compound 3, dose for 50% inhibition: 5.7 umol/kg
Beside the measured number, compound 3's estimate is 1.1-fold (0.02 log units) above it; measured number inside the range.
By their numbers in this assay, from the lowest: compound 1; then compound 3; then compound 2.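

In this assay, a single methyl on a saturated ring carbon, two ring bonds from the ring nitrogen, brings a 5.5-fold lower number from compound 2 to compound 3 (0.74 log units; beyond the scatter), so a methyl at this place also goes with a lower number, a link that until now rested only on compound 1, whose methyl sits elsewhere on the ring. The position of the methyl also counts among these compounds: compound 3 gives 5.7 umol/kg, while compound 1 gives 0.6 umol/kg. No measurement on record explains why this methyl lowers the dose needed.

At this ring carbon only hydrogen and methyl can be compared so far, and two points do not make a trend. From the compounds shown here alone, whether an ethyl, a longer chain or a hydroxyl at the same carbon would lower the number further, or raise it again, remains open.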